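Working notes: ether-side substituent changes on the shared core

A few compounds are considered here, and "the series" means these few. Any claim that something is new, unique, unknown or untested is made for them only; others in the source may bear on it.

Measured so far:
compound 1 `Cc1nn(-c2ncnc3nc[nH]c23)c2c1C(OCc1ccccc1F)CC(=O)N2`: 78 nM
compound 2 `Cc1nn(-c2ncnc3nc[nH]c23)c2c1C(OCc1ccc(C#N)cc1)CC(=O)N2`: 60 nM

In a functional assay on HEK293 cells for agonist activity at G-protein coupled receptor 39 (Homo sapiens), read by scintillation proximity assay and inositol phosphate accumulation, with a stated time of 75 min (a lower number here means that less compound is needed, a higher number that more compound is needed for the effect), compound 2 gives the lowest of the two numbers, with compound 1 nearest at 78 nM; the step of a 1.3-fold lower number from compound 1 to compound 2 (0.11 log units; within the scatter) is within the scatter, so the two compounds cannot be ordered.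

Compound 3 `Cc1nn(-c2ncnc3nc[nH]c23)c2c1C(OCCn1nccc1C)CC(=O)N2` is not yet measured. It differs from compound 2 by (5-methyl-1H-pyrazol-1-yl)methyl in place of 4-cyanophenyl on a saturated chain carbon bound to an oxygen on a saturated carbon.

Among the compounds with values here, the only measured step, a 1.3-fold lower number from compound 1 to compound 2 (0.11 log units; within the scatter), concerns the same place and shows that exchanging one six-membered aromatic ring for another moved the number by less than the scatter. Within the data shown here, the change to compound 3 replaces the aromatic ring with a five-membered heteroaromatic ring carried on an additional saturated carbon, which no measured pair covers; the data give no basis for predicting a large step in either direction.

Compound 3 is therefore expected to land near compound 2, with the step of a 1.8-fold higher number from compound 2 to compound 3 (0.26 log units; within the scatter) likely within or only slightly beyond the scatter. The estimate for compound 3 in this assay is 110 nM, with a range from 35 nM to 350 nM.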

Compound 3, half-maximal effective concentration: 1620 nM
Compound 3: middle estimate off by 15-fold (1.17 log units), on the low side, outside the stated range (above it).
By their numbers in this assay, from the lowest: compounds 2 and 1 (each within the scatter of the next); then compound 3.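

In this assay this place on the ether side turns out to be sensitive: (5-methyl-1H-pyrazol-1-yl)methyl in place of 4-cyanophenyl gives a 27-fold higher number from compound 2 to compound 3 (1.43 log units; beyond the scatter) and, in place of 2-fluorophenyl, a 21-fold higher number from compound 1 to compound 3 (1.32 log units; beyond the scatter) as well. The change between the two six-membered aromatic rings of carbon only had stayed within the scatter, so that pair gave no sign that a change at this place could produce a large step. Nothing available bears on the cause of the step.

The entering group brings a five-membered aromatic ring with 2 hetero atoms and a methyl link together, leaving open which of the two goes with the large step. Also open, as far as these compounds go, is how a phenyl ring bearing an amine or a carboxylic acid, or a longer chain, would fare at this place.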